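The source may hold more compounds than are shown below. What is called first, only, known or untested is meant among the compounds shown, and "the series" means these compounds.

The study follows a small set of compounds that share one core and differ only at an amine nitrogen in a six-membered non-aromatic ring with two nitrogens. Compound 1 `O=C1Cc2cc(S(=O)(=O)N3CCNCC3)ccc2N1` carries a hydrogen on that nitrogen; in an assay on isolated protein for inhibition of lysosomal alpha-glucosidase (Homo sapiens), read by fluorescence, with stated times of 5 min and 45 min (a lower number here means a stronger inhibitor, a higher number a weaker inhibitor), compound 1 is reported as "not active" (no number reported), so no single number marks where it stands. Compound 2 `O=C1Cc2cc(S(=O)(=O)N3CCN(c4ccc(O)cc4)CC3)ccc2N1` carries a 4-hydroxyphenyl there; in this assay compound 2 gives 2370 nM. Compound 3 `Cc1ccc(N2CCN(S(=O)(=O)c3ccc4c(c3)CC(=O)N4)CC2)cc1` has not yet been measured. Its difference from compound 1 is 4-methylphenyl in place of hydrogen on an amine nitrogen in a ring. Going by the values given here, no measured step is recorded for this change, so its size is open; the reading for compound 1 suggests the move toward a number is likely downward, toward a stronger inhibitor, beyond the usual scatter, though the amount cannot be judged. Compound 3 is expected to give 3000 nM, within a range of 800 nM to 15000 nM.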

Compound 3, half-maximal inhibitory concentration: "not active" (no number reported)
Compound 3 has no reported number here; the estimate stays without a comparison.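

Compound 3, like compound 1, carries no number in this assay, so no step can be read between them. No evidence on hand bears on this result. The compounds shown leave open how the 4-methylphenyl of compound 3 and the 4-hydroxyphenyl of compound 2 compare in this assay.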